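The compounds below may be only part of what the source reports. "The series", "measured", "known", "first", "only" and "open" are said of these compounds alone.

Within the data shown here, in an ADME assay on BaF3 cells (Mus musculus) for cytotoxicity (a lower number here means that less compound is needed, a higher number that more compound is needed for the effect), compound 1 `O=C(Nc1cccc(C(F)(F)F)c1)c1cccc(-c2ccc3nc(NC(=O)C4CC4)sc3n2)c1` gives 910 nM, the only exact number so far. Compound 2 `O=C(Nc1nc2ccc(-c3cccc(C(=O)Nc4cccc(C(F)(F)F)c4)c3)nc2s1)NC1CCNCC1` gives > 10000 nM, which is a limit of the assay. Among the measured compounds shown here, the one measured step, an at least 10-fold higher number from compound 1 to compound 2 (1.04 log units; beyond the scatter), is large, but it lies at a different place, on a carbonyl carbon. Compound 3 `O=C(Nc1ccc(-n2ccnc2)cc1)c1cccc(-c2ccc3nc(NC(=O)C4CC4)sc3n2)c1` instead has 4-(1H-imidazol-1-yl)phenyl in place of 3-(trifluoromethyl)phenyl on an amide-type nitrogen. For the measured compounds named here, no measured step covers this change, so that large step bears on it only indirectly, and a moderate rise in this assay is expected. The expected step is a 2.2-fold higher number from compound 1 to compound 3 (0.34 log units; beyond the scatter). For compound 3 the estimated value is 2000 nM, within an expected range of 500 nM to 8000 nM.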

Compound 3, half-maximal effective concentration: > 10000 nM
Compound 3 gave a limit, no number (the forecaster's own chance of this, stated with the estimate: 15%); middle value at least 5.0-fold (0.69 log units) away from the limit.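

At the amide-type nitrogen, 4-(1H-imidazol-1-yl)phenyl in place of 3-(trifluoromethyl)phenyl gives in this assay an at least 10-fold higher number from compound 1 to compound 3 (1.04 log units; beyond the scatter), so a large step is no longer confined to the change on the carbonyl carbon. The value of compound 3 is a limit, not a number, so this step gives only a minimum size. Compound 3 also cannot be ranked against compound 2: the limit of > 10000 nM in this assay, at which 2 of the 3 values shown sit.

The compounds shown leave open whether the imidazole ring or the loss of trifluoromethyl matters here. On these data alone, how a plain phenyl, a chlorophenyl or a methoxyphenyl group would behave at this nitrogen also remains open.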